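The source may report more compounds than this note shows. Statements on the series, on what has been measured and on what is new or still open speak of the compounds shown alone.

Compound 1 `C=C1C[C@]23C[C@@]1(O)CC[C@H]2c1cc(Br)c(O)c(C)c1[C@@H]3Cn1cc(-c2ccc(C)cc2)nn1` sits at the limit of a functional assay on MCF7 cells (Homo sapiens) for cytotoxicity, read by MTT assay, with a stated time of 4 days (on this read-out lower numbers stand for stronger inhibition and higher numbers for weaker inhibition), giving > 20000 nM, which is a limit of the assay and not a number. Compound 2 `Cc1c(O)ccc2c1[C@H](Cn1cc(-c3ccccc3)nn1)[C@@]13CC(=O)[C@@](C)(CC[C@@H]21)C3` also returns only a limit, > 20000 nM. Within the data shown here, both values shown are limits (the limit of > 20000 nM in this assay, at which 2 of the 2 values shown sit), so compound 1 stands level with the only other value shown, with nothing numerical to rank. Compound 3 `C=C1C[C@]23C[C@@]1(O)CC[C@H]2c1cc(Br)c(O)c(C)c1[C@@H]3Cn1cc(-c2ccc(Cl)cc2)nn1` differs from compound 1 by chloro in place of methyl on an aromatic carbon. Among the measured compounds shown here, no measured step resembles this change. In this assay the step is expected to bring no movement beyond the scatter, a step that the limit leaves unreadable from compound 1 to compound 3. Compound 3 is expected to give 30000 nM, within 8000 nM to 100000 nM, most likely again reported only as a limit.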

Compound 3, half-maximal inhibitory concentration: 10200 nM
For compound 3 the middle estimate is 2.9-fold (0.47 log units) above the measured one, within the range that was stated.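

Among these compounds, with chloro in place of methyl on the aromatic carbon para to a large group, compound 3 is the first compound here to return a number rather than a limit in this assay. The step reads an at least 1.9-fold lower number from compound 1 to compound 3 (0.29 log units; that floor lies within the scatter), so a real gain from 4-methylphenyl to 4-chlorophenyl is not established. Its true size cannot be read, with compound 1 held at a limit: the limit of > 20000 nM in this assay, at which 2 of the 3 values shown sit.

Open, from the compounds shown here alone, is how an amine or a carboxylic acid at this same place would read on the core of compound 1. Compound 2 differs from both in more than one place and offers no comparison.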